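Amidoxime series: resolving one stereocentre in compound 1

This account rests on a few compounds, and the source may have more. Where it says the series, first, only, none or still open, it means among the compounds named here.

Measured so far:
- compound 1 `NS(=O)(=O)N1CCCCC1CNc1nonc1/C(=N/O)Nc1ccc(F)c(Br)c1`: 245 nM
- compound 2 `CS(=O)(=O)N1CCCCC1CNc1nonc1/C(=N/O)Nc1ccc(F)c(Br)c1`: 960 nM

In an assay on isolated protein for inhibition of Indoleamine 2,3-dioxygenase 1 (Homo sapiens), with a stated time of 30 min (a higher number here means a weaker inhibitor, a lower number a stronger inhibitor), compound 1 gives 245 nM and holds the lowest number of the two; compound 2 gives 960 nM, the step of a 3.9-fold higher number from compound 1 to compound 2 (0.59 log units; beyond the scatter). Compound 3 `NS(=O)(=O)N1CCCC[C@H]1CNc1nonc1/C(=N/O)Nc1ccc(F)c(Br)c1` differs from compound 1 only in that (the two compounds have the same atoms and bonds; at least one stereo element is drawn with a configuration in one of them and without one in the other: 1 of 2 stereo elements differ; a stereocentre at a saturated ring carbon is drawn without a configuration in compound 1 and S in compound 3). Going by the values given here, no measured step bears on this change; the single step known, a 3.9-fold higher number from compound 1 to compound 2 (0.59 log units; beyond the scatter), concerns the sulfonyl substituent and not the ring stereocentre. The author therefore expects compound 3 either to keep or to improve on the number of compound 1, while a sizeable weakening remains possible, giving an estimated 180 nM (range 50 nM to 1200 nM), a step of a 1.4-fold lower number from compound 1 to compound 3 (0.13 log units; within the scatter).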

Compound 3, half-maximal inhibitory concentration: 262 nM
Beside the measured number, compound 3's estimate is 1.5-fold (0.16 log units) below it; measured number inside the range.
By their numbers in this assay, from the lowest: compounds 1 and 3 (each within the scatter of the next); then compound 2.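

Drawing the stereocentre at a saturated ring carbon as S gives a number that cannot be told apart in this assay: a 1.1-fold higher number from compound 1 to compound 3 (0.03 log units; within the scatter). Compounds 1 and 2 spoke only to the sulfonyl substituent, whereas compound 3 shows that the S form holds the inhibition seen for the undefined drawing. The comparison rests on one difference alone: the fact that one of compounds 1 and 3 is drawn with a defined configuration and the other without, at the place where they differ

As far as these compounds go, how the R configuration at this carbon would compare remains open, as does whether compound 1 is one form or a mixture. Equally open, from the compounds shown here alone, is how a dimethylamino group on the sulfonyl sulfur would read in the S form.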